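A few compounds are considered here, and "the series" means these few. Any claim that something is new, unique, unknown or untested is made for them only; others in the source may bear on it.

Compound 1 `Oc1ccccc1-c1cc(-c2ccc(F)cc2)cc(-c2ccccc2O)n1` gives in a functional assay on T47D cells (Homo sapiens) for inhibition (on this read-out higher numbers stand for weaker inhibition and lower numbers for stronger inhibition), a result of > 50000 nM, a limit of the assay rather than a number.
Compound 2 `Oc1ccc(-c2cc(-c3cccc(F)c3)cc(-c3ccccc3O)n2)cc1` gives in this assay a result of > 50000 nM, again a limit.
Compound 3 `Oc1ccc(-c2cc(-c3ccc(F)cc3)cc(-c3ccccc3O)n2)cc1` gives in this assay a result of > 50000 nM, once more a limit.

On the numbers shown, compound 3 stands at the limit of > 50000 nM in this assay, at which 3 of the 3 values shown sit, so its position is known only as a limit. Compound 4 `Oc1ccc(-c2cc(-c3ccc(F)cc3)cc(-c3ccc(O)cc3)n2)cc1` differs from compound 3 in one place: 4-hydroxyphenyl in place of 2-hydroxyphenyl on an aromatic carbon. Of the measured steps, the one that bears most directly on this change is a step that the two limits leave unreadable from compound 1 to compound 3, the same exchange of a 2-hydroxyphenyl for a 4-hydroxyphenyl, and its size cannot be read because both ends sit at the limit. The step that the two limits leave unreadable from compound 2 to compound 3 concerns the fluorophenyl instead and is equally unreadable. With every shown value at the limit, no step can be sized, and there is no basis to expect compound 4 to move beyond the scatter in either direction in this assay. The expected step from compound 3 to compound 4 is therefore a number no higher from compound 3 to compound 4 (the limit leaves the size open). Compound 4 is expected to give 50000 nM in this assay, within a range of 15000 nM to 200000 nM, most likely again as a limit.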

Compound 4, half-maximal inhibitory concentration: 5260 nM
Compound 4: middle estimate off by 9.5-fold (0.98 log units), on the high side, outside the stated range (below it).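

In this assay, exchanging 2-hydroxyphenyl for 4-hydroxyphenyl on the aromatic carbon next to the ring nitrogen gives the first readable step among these compounds: an at least 9.5-fold lower number from compound 3 to compound 4 (0.97 log units; beyond the scatter). The earlier steps shown here cannot be read, so the same exchange from compound 1 to compound 3 could not show whether this position responds at all, whereas the step to compound 4 shows that it does. Compound 4 carries no 2-hydroxyphenyl group and is the only compound shown with a number, while the other three stop at a limit of the assay: the limit of > 50000 nM in this assay, at which 3 of the 4 values shown sit.

On these data alone, the true position of compound 3 beyond its limit remains unknown, which leaves open how much larger the step to compound 4 may be. Also open, as far as these compounds go, is whether the hydroxyl itself matters in this position, that is, whether an amine or a carboxylic acid on the phenyl ring in its place would keep, strengthen or lose the inhibition seen with compound 4 in this assay.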